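The source may hold more compounds than are shown below. What is called first, only, known or untested is meant among the compounds shown, and "the series" means these compounds.

Compound 2 `COc1ccc(-c2cc3ccccc3nc2/C=C/C(=O)c2ccccn2)cc1` is the starting point here. In a functional assay on SK-BR-3 cells (Homo sapiens) for antiproliferative activity, read by XTT assay, with a stated time of 72 h (on this read-out lower numbers stand for stronger inhibition and higher numbers for weaker inhibition), compound 2 gives 370 nM. Among the measured compounds shown here, its only measured neighbour is compound 1 `COc1ccc(-c2cc3ccccc3nc2/C=C/C(=O)c2ccc([N+](=O)[O-])cc2)cc1`, which in this assay gives 590 nM. The step of a 1.6-fold lower number from compound 1 to compound 2 (0.20 log units; within the scatter) lies within the scatter, so the two compounds sit together rather than apart. Compound 3 `COc1ccc(-c2cc3ccccc3nc2/C=C/C(=O)c2cnc(N)nc2C)cc1` has not been measured. It differs from compound 2 in one place: 2-amino-4-methylpyrimidin-5-yl in place of pyridin-2-yl on a carbonyl carbon. For the measured compounds named here, the one measured step that bears on this change is a 1.6-fold lower number from compound 1 to compound 2 (0.20 log units; within the scatter), which also exchanged the aromatic ring on the carbonyl carbon and did not move the number beyond the scatter. On that basis the expected step is a 1.1-fold higher number from compound 2 to compound 3 (0.03 log units; within the scatter), no larger than the scatter and in no clear direction. The estimate for compound 3 in this assay is 400 nM, with a range from 150 nM to 1000 nM.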

Compound 3, half-maximal inhibitory concentration: > 10000 nM
Compound 3: only a limit was reported; the forecaster's own chance of this, stated with the estimate: 2%; middle value at least 25-fold (1.39 log units) away from the limit.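

The ring on the carbonyl carbon turns out to matter far more than the earlier pair suggested: 2-amino-4-methylpyrimidin-5-yl in place of pyridin-2-yl gives an at least 27-fold higher number from compound 2 to compound 3 (1.43 log units; beyond the scatter), and in place of 4-nitrophenyl it gives an at least 16-fold higher number from compound 1 to compound 3 (1.22 log units; beyond the scatter). Compound 3 reaches only a limit of the assay, not a number: the limit of > 10000 nM in this assay, at which 1 of the 3 values shown sits. So two different aromatic rings at this position sit together within the scatter, yet this third ring stands well apart from both, and exchanging the ring here is not a neutral change.

The entering group brings an amino group, a methyl group and a further ring nitrogen all at once, and these three compounds cannot say which of them accounts for the step. A plain pyrimidin-5-yl or a 2-aminopyrimidin-5-yl on the same carbonyl carbon would begin to separate these features.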